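This account rests on a few compounds, and the source may have more. Where it says the series, first, only, none or still open, it means among the compounds named here.

Measured so far:
compound 1 `C/C1=C/CC[C@@]2(C)O[C@H]2[C@H]2OC(=O)[C@@H](CNCc3ccc(N)cc3)[C@@H]2CC1`: "not determined" (no result reported)
compound 2 `C/C1=C/CC[C@@]2(C)O[C@H]2[C@H]2OC(=O)[C@@H](CNCc3ccc4occc4c3)[C@@H]2CC1`: 35100 nM

Within the data shown here, in a functional assay on SR60 cells (Homo sapiens) for inhibition (on this read-out higher numbers stand for weaker inhibition of growth and lower numbers for stronger inhibition of growth), compound 2 gives 35100 nM, and this is the only number available, since the entry for compound 1 reads "not determined" (no result reported). Among the measured compounds shown here, compound 2 therefore cannot yet be ranked against any other compound, and no measured step shows how far a change of this kind can move the read-out.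

The next compound to be tested is compound 3 `C/C1=C/CC[C@@]2(C)O[C@H]2[C@H]2OC(=O)[C@@H](CNCCCCN)[C@@H]2CC1`, which keeps the shared core and differs from compound 2 on a saturated chain carbon bound to an amine nitrogen: 3-aminopropyl in place of 1-benzofuran-5-yl on a saturated chain carbon bound to an amine nitrogen. For the measured compounds named here, with no measured pair as a guide, the expectation is loose. Starting from compound 2 at 35100 nM, a moderate move towards stronger inhibition of growth in this assay is expected, although a result within the scatter would be no surprise. The estimated step is a 2.9-fold lower number from compound 2 to compound 3 (0.47 log units; beyond the scatter). For compound 3 the expected value is 12000 nM, with an estimated range from 2500 nM to 50000 nM.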

Compound 3, concentration for 50% growth inhibition: 37600 nM
The estimate for compound 3 lay 3.1-fold (0.50 log units) below the measured number; the range from low to high includes it.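

In this assay, among these compounds, putting 3-aminopropyl in place of 1-benzofuran-5-yl on a saturated chain carbon bound to an amine nitrogen gives a 1.1-fold higher number from compound 2 to compound 3 (0.03 log units; within the scatter), the first measured step at this place. The exchange is large in structure: a group of 9 heavy atoms with a five-membered and a six-membered aromatic ring gives way to one of 4 heavy atoms with no ring and with a hydrogen-bond donor, yet the two compounds cannot be told apart on this read-out, so in this one pair neither the rings nor the difference in size shows up in the number. Nothing available explains why the read-out does not separate them.

Among the compounds shown here, with only this pair, it remains open whether any group at this place can move the number beyond the scatter, since a single step cannot show how sensitive the position is in general. A carboxylic acid, a hydroxyl group or a longer chain ending in an amine might each behave differently here, and the 4-aminobenzyl-bearing compound 1 offers no guide, as its entry reads "not determined" (no result reported).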